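The compounds below may be only part of what the source reports. "The series", "measured", "known", "first", "only" and "open" are said of these compounds alone.

Compound 1 `Cc1ccc(C2(CNC(=O)Nc3c(C(C)C)cccc3C(C)C)CCCC2)cc1`: 25 nM
Compound 2 `CC(C)c1cccc(C(C)C)c1NC(=O)NCC1(c2ccccc2C(F)(F)F)CCCC1`: 18 nM
Compound 3 `CC(C)c1cccc(C(C)C)c1NC(=O)NCC1(c2ccc(NCCO)cc2)CCCC1`: 25 nM

Three ureas built on a shared core have been measured in an assay on microsomes for inhibition of acyl-CoA:cholesterol acyltransferase (Oryctolagus cuniculus); on this read-out higher numbers stand for weaker inhibition and lower numbers for stronger inhibition. Compound 1 gives 25 nM, compound 2 gives 18 nM and compound 3 gives 25 nM. Compound 3 stands level with compound 1 at the digits shown, the two together the highest of the three numbers, and the step of a 1.4-fold higher number from compound 2 to compound 3 (0.14 log units; within the scatter) is its largest distance to any other compound; every step among the three lies within the scatter, so nothing separates them.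

Compound 4 `CC(C)c1cccc(C(C)C)c1NC(=O)NCC1(c2cccc(C(=O)O)c2)CCCC1` differs from compound 3 in one place: 3-carboxyphenyl in place of 4-((2-hydroxyethyl)amino)phenyl on a saturated ring carbon. Among the measured compounds shown here, the steps that bear on this change are the two earlier swaps of the aryl group on the same saturated ring carbon, a 1.4-fold lower number from compound 1 to compound 2 (0.14 log units; within the scatter) and a 1.4-fold higher number from compound 2 to compound 3 (0.14 log units; within the scatter), together with the change on an aromatic carbon, no change at the digits printed from compound 1 to compound 3 (within the scatter). None of them moved the number beyond the scatter, and none introduced a carboxylic acid, so the data hold nothing direct on that group. The expected step is therefore a 1.2-fold higher number from compound 3 to compound 4 (0.08 log units; within the scatter), no change beyond the scatter. The estimate for compound 4 in this assay is 30 nM, with a range from 12 nM to 90 nM.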

Compound 4, half-maximal inhibitory concentration: 620 nM
Beside the measured number, compound 4's estimate is 21-fold (1.32 log units) below it, outside the stated range (above it).
By their numbers in this assay, from the lowest: compounds 2, 1 and 3 (each within the scatter of the next); then compound 4.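

In this assay, among the compounds shown here, the saturated ring carbon had so far taken three different aryl groups with no change beyond the scatter, so it looked open to almost any aryl group. The 3-carboxyphenyl group ends that picture, with a 25-fold higher number from compound 3 to compound 4 (1.39 log units; beyond the scatter) and a 25-fold higher number from compound 1 to compound 4 (1.39 log units; beyond the scatter) and also a 34-fold higher number from compound 2 to compound 4 (1.54 log units; beyond the scatter) as large steps from all three earlier compounds. The position therefore does not accept every aryl group, though nothing shown says why this one costs so much.

Compound 4 alone carries a carboxylic acid and alone carries its substituent at the 3-position of the phenyl ring, so the compounds shown cannot separate the two. A 4-carboxyphenyl group would address that, while a methyl ester, a primary amide or a carboxylic acid on a longer chain would test whether the acid itself matters.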